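Methoxy to Fluoro on Two Diester Cores

This account rests on a few compounds, and the source may have more. Where it says the series, first, only, none or still open, it means among the compounds named here.

Compound 1 `COc1cccc(OC(=O)c2cc(O)cc(O)c2)c1OC(=O)c1cc(O)cc(O)c1` gives 69.4% in a functional assay on NCI-H1299 cells (Homo sapiens) for inhibition, read by scintillation counting, with a stated time of 30 min, tested at 30 uM; on this read-out higher numbers stand for more inhibition at the one concentration tested (going by the name of the read-out) and lower numbers for less inhibition. Compound 2 `O=C(Oc1cccc(F)c1OC(=O)c1cc(O)cc(O)c1)c1cc(O)cc(O)c1` differs from it by fluoro in place of methoxy on an aromatic carbon, and in this assay compound 2 gives 94%, which is a number 24.6 percentage points higher from compound 1 to compound 2 (beyond the scatter). Compound 3 `COc1cccc(OC(=O)c2ccccc2O)c1OC(=O)c1ccccc1O` rests on a different core; how that core differs from the core of compound 1 is not broken down here. In this assay compound 3 gives 50.5%, the lowest of the three numbers. Compound 4 `O=C(Oc1cccc(F)c1OC(=O)c1ccccc1O)c1ccccc1O` is derived from compound 3 by fluoro in place of methoxy on an aromatic carbon, the same change made from compound 1 to compound 2. A step of similar size is expected for compound 4 because a number 24.6 percentage points higher from compound 1 to compound 2 (beyond the scatter) lay beyond the scatter, though a single pair on another core is thin ground. Compound 4 is thus expected to give about 70% in this assay, an expected step of a number 19.5 percentage points higher from compound 3 to compound 4 (beyond the scatter).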

Compound 4, a percentage reported as inhibition, at one concentration (the size of the read-out at that concentration, not a potency): 51%
Estimate against measurement, compound 4: 19 percentage points above; measured number outside the range, below it.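

On the other core, fluoro in place of methoxy on an aromatic carbon gives a number 0.5 percentage points higher from compound 3 to compound 4 (within the scatter) in this assay, so the gain seen on the core of compound 1 did not carry over to the core of compound 3. The effect of this change in this series therefore depends on the core, and the two steps differ: the same change on two cores in this assay, a number 24.6 percentage points higher (beyond the scatter) from compound 1 to compound 2 and a number 0.5 percentage points higher (within the scatter) from compound 3 to compound 4, 24.1 percentage points apart, beyond the scatter of two such steps. Within the data shown here, this rests on only two pairs, however, and it does not show which feature of the cores accounts for the difference, nor how the change would behave on any further core.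

The compounds shown leave open how a chloro group or an amine in that place would read on either core. They also leave open whether a third core would follow compound 1 and compound 2 or compound 3 and compound 4.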